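Pyrrolecarbonyl esters of two nucleoside cores: inhibition notes

The compounds below may be only part of what the source reports. "The series", "measured", "known", "first", "only" and "open" are said of these compounds alone.

Four compounds share a pyrrolecarbonyl ester on the sugar of a nucleoside, and two cores carry it. Compound 1 `Nc1ncnc2c1ncn2[C@@H]1O[C@H](COC(=O)c2cc[nH]c2)[C@@H](O)[C@H]1O` and compound 2 `Nc1ncnc2c1ncn2[C@@H]1O[C@H](COC(=O)c2ccc[nH]2)[C@@H](O)[C@H]1O` have one core; compound 3 `Nc1nc2c(ncn2[C@@H]2O[C@H](COC(=O)c3cc[nH]c3)[C@@H](O)[C@H]2O)c(=O)[nH]1` and compound 4 `Nc1nc2c(ncn2[C@@H]2O[C@H](COC(=O)c3ccc[nH]3)[C@@H](O)[C@H]2O)c(=O)[nH]1` have the other. The difference between the two cores is not broken down here.

In an assay for inhibition of MAP kinase-activated protein kinase 2 (Homo sapiens), read by Z'-LYTE, with a stated time of 1 h, tested at 10 uM (a lower number here means less inhibition, a higher number more inhibition at the concentration tested (going by the name of the read-out)), compound 1 gives 87%. Compound 2 gives 95% in this assay. The change between them is 1H-pyrrol-2-yl in place of 1H-pyrrol-3-yl on a carbonyl carbon; it made a step of a number 8 percentage points higher from compound 1 to compound 2 (within the scatter).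

Compound 3 gives 82% in this assay. Its number stands within the scatter of compound 1 and beyond the scatter of compound 2, so no order can be read between compound 3 and compound 1.

Compound 4 is not yet measured in this assay. It differs from compound 3 by 1H-pyrrol-2-yl in place of 1H-pyrrol-3-yl on a carbonyl carbon, the same change as that from compound 1 to compound 2, made on the same kind of carbonyl carbon. The expected step from compound 3 to compound 4 is a number 6 percentage points higher from compound 3 to compound 4 (within the scatter), a size taken from the step seen from compound 1 to compound 2, which was a number 8 percentage points higher from compound 1 to compound 2 (within the scatter). On this basis compound 4 is estimated to give 88% in this assay, expected to fall between 78% and 96%. The estimate rests on a single prior pair, so it is weakly founded.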

Compound 4, a percentage reported as inhibition, at one concentration (the size of the read-out at that concentration, not a potency): 88%
The estimate for compound 4 equals the measured number at the digits printed; the range from low to high includes it.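

In this assay the change to 1H-pyrrol-2-yl in place of 1H-pyrrol-3-yl on a carbonyl carbon, made on the second core, gives a number 6 percentage points higher from compound 3 to compound 4 (within the scatter), and the two steps for this change do not differ: the same change on two cores in this assay, a number 8 percentage points higher (within the scatter) from compound 1 to compound 2 and a number 6 percentage points higher (within the scatter) from compound 3 to compound 4, 2 percentage points apart, within the scatter of two such steps. Within these four compounds, then, the change carries from one core to the other with a step of like size. This does not show that the change itself alters inhibition, as each step lies within the scatter, and two cores read at one concentration say nothing about potency or about any further core.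

Open is whether the pyrrole is needed at all, as a longer alkyl chain, an amine or a carboxylic acid in its place has no reading among the compounds shown. Also open, from the compounds shown here alone, is the part played by the ester link, which an amide could test, and whether the same step would hold for a pyrrole carrying a methyl group on its nitrogen, where the hydrogen-bond donor counted in both groups would be gone.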